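Changing the amino substituent on compound 3's aniline ring

The source may report more compounds than this note shows. Statements on the series, on what has been measured and on what is new or still open speak of the compounds shown alone.

Measured compounds:
Compound 1, `O=S(=O)(/C=C/c1c(F)c(F)c(F)c(F)c1F)Nc1c(F)c(F)c(F)c(F)c1F`, gives 35000 nM.
Compound 2, `COc1ccc(NS(=O)(=O)/C=C/c2c(OC)cc(O)cc2OC)cc1`, gives 10000 nM.
Compound 3, `COC(=O)C(C)(C)Nc1cc(NS(=O)(=O)/C=C/c2c(OC)cc(OC)cc2OC)ccc1OC`, gives 200 nM.

All three were tested in a functional assay on DU-145 cells (Homo sapiens) for cytotoxicity, read by trypan blue exclusion, with a stated time of 96 h; a lower number here means a stronger inhibitor, a higher number a weaker inhibitor. Among them compound 3 stands lowest; the gap to compound 2, its nearest neighbour, and the larger gap to compound 1 both lie beyond the scatter, so compound 3 is the strongest inhibitor of the three in this assay.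

Compound 4, `COc1cc(OC)c(/C=C/S(=O)(=O)Nc2ccc(OC)c(NC(C(=O)O)c3ccc(Br)cc3)c2)c(OC)c1`, has not yet been measured. It differs from compound 3 in one place: (4-bromophenyl)(carboxy)methyl in place of 1-(methoxycarbonyl)-1-methylethyl on a nitrogen on an aromatic ring. Among the measured compounds shown here, no step between two measured compounds mirrors this exchange, so the expectation rests on compound 3 alone. With compound 3 at 200 nM as the anchor, the (4-bromophenyl)(carboxy)methyl group is expected to leave the potency roughly intact or to weaken it modestly; a step of a 2.0-fold higher number from compound 3 to compound 4 (0.30 log units; within the scatter) toward a higher number is the estimate, near the edge of the scatter. Compound 4 is therefore estimated at 400 nM, with a range from 100 nM to 2000 nM.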

Compound 4, half-maximal inhibitory concentration: 250 nM
Estimate against measurement, compound 4: 1.6-fold (0.20 log units) above; the range from low to high includes it.
By their numbers in this assay, from the lowest: compounds 3 and 4 (each within the scatter of the next); then compound 2; then compound 1.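

In this assay, putting (4-bromophenyl)(carboxy)methyl in place of 1-(methoxycarbonyl)-1-methylethyl on the nitrogen gives a 1.3-fold higher number from compound 3 to compound 4 (0.10 log units; within the scatter), so the two groups cannot be told apart in this read-out. Compounds 1 and 2 each differ from compound 3 in more than one place and said nothing about this nitrogen, whereas this pair shows that its substituent can go from 7 heavy atoms without a ring to 11 heavy atoms with a six-membered aromatic ring, a bromine and a hydrogen-bond donor, and the potency stays within the scatter. Nothing measured in these compounds offers a reason for this outcome.

Open, from the compounds shown here alone, is which part of the exchange matters, since the ester gave way to a carboxylic acid and the two methyl groups to a 4-bromophenyl ring in one step, and the methyl ester of compound 4 or a 1-carboxy-1-methylethyl group on the same nitrogen would separate the two. Also open, going by these compounds, is how the shared core behaves with a plain amine at this place, or with a chloro or methoxy group in place of the bromine.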